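This account rests on a few compounds, and the source may have more. Where it says the series, first, only, none or still open, it means among the compounds named here.

Compound 1, `CN/C(=N/C#N)NCCCCCn1ccnc1C`, was tested in a functional assay on Sf9 cells for antagonist activity at histamine H2 receptor (Homo sapiens), read by scintillation counting and GTPgammaS binding, with a stated time of 90 min; on this read-out lower numbers stand for lower potency and higher numbers for higher potency (the scale is a negative logarithm). In this assay compound 1 gives only a limit of < 5, not a number. Compound 2, `Cc1nccn1CCCCCN/C(=N\C#N)NCCSc1ccccc1`, differs from it by one change, ((phenylsulfanyl)methyl in place of hydrogen on a saturated chain carbon bound to an amine nitrogen). In this assay compound 2 also gives only a limit of < 5. The step that the two limits leave unreadable from compound 1 to compound 2 cannot be sized because of the limit of < 5 in this assay, at which 3 of the 3 values shown sit. Compound 3, `CN/C(=N\C#N)NCCCSc1nc(N)n[nH]1`, has a different core; how its core differs from that of compound 1 is not broken down here. In this assay compound 3 too gives only a limit of < 5. Compound 4, `N#C/N=C(/NCCCSc1nc(N)n[nH]1)NCCSc1ccccc1`, is not yet measured and differs from compound 3 by the same change, ((phenylsulfanyl)methyl in place of hydrogen on a saturated chain carbon bound to an amine nitrogen). Within the data shown here, the measured step offers no size to carry over, and every value so far sits at the limit, so compound 4 is expected near 4.7 in this assay, a step that the limit leaves unreadable from compound 3 to compound 4 that is an estimate only. Compound 4 is expected to fall between 4 and 5.5 in this assay.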

Compound 4, negative logarithm of the antagonist equilibrium constant: < 5
Compound 4 gave a limit, no number (the forecaster's own chance of this, stated with the estimate: 70%); the middle value does not contradict the limit.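

No size can be read for the step from compound 3 to compound 4, because in this assay both compounds give only a limit, not a number: the limit of < 5 in this assay, at which 4 of the 4 values shown sit.

The compounds shown leave open whether putting (phenylsulfanyl)methyl in place of hydrogen at this chain carbon changes potency at all, in either pair.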